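Aryl sulfonate ureas: removing the chloromethyl terminus

A few compounds are considered here, and "the series" means these few. Any claim that something is new, unique, unknown or untested is made for them only; others in the source may bear on it.

Of the compounds shown here, three have been tested in a functional assay on M21 cells (Homo sapiens) for cytotoxicity, read by sulforhodamine B assay, with a stated time of 48 h; on this read-out higher numbers stand for weaker inhibition and lower numbers for stronger inhibition. Compound 1 `CCCc1ccccc1OS(=O)(=O)c1cccc(NC(=O)NCCCCl)c1` gives 15000 nM in this assay. Compound 3 `CCCc1ccccc1OS(=O)(=O)c1cccc(NC(=O)NCC)c1` gives 25000 nM in this assay. Compound 2 `Cc1ccccc1OS(=O)(=O)c1ccc(NC(=O)NCCCCl)cc1` gives 25000 nM in this assay, level with compound 3 at the digits given. The difference between the core of compound 1 and the core of compound 2 is not broken down here.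

Compound 4 `CCNC(=O)Nc1ccc(S(=O)(=O)Oc2ccccc2C)cc1` has not yet been measured. It arises from compound 2 by the change (hydrogen in place of chloromethyl on a saturated chain carbon, two bonds along the chain from an amide-type nitrogen). The same change has been made once before, from compound 1 to compound 3, as hydrogen in place of chloromethyl on a saturated chain carbon, two bonds along the chain from an amide-type nitrogen, and there the step was a 1.7-fold higher number from compound 1 to compound 3 (0.22 log units; within the scatter).

On the strength of that single precedent, the step from compound 2 to compound 4 in this assay is expected to be a 1.6-fold higher number from compound 2 to compound 4 (0.20 log units; within the scatter), resting on the step from compound 1 to compound 3, with the caution that the precedent lies within the scatter and the cores differ. Compound 4 is therefore estimated at 40000 nM in this assay, in the range 20000 nM to 90000 nM.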

Compound 4, half-maximal inhibitory concentration: 3100 nM
Estimate against measurement, compound 4: 13-fold (1.11 log units) above, outside the stated range (below it).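

In this assay the change from 3-chloropropyl to ethyl gives an 8.1-fold lower number from compound 2 to compound 4 (0.91 log units; beyond the scatter) on the core of compound 2, a step beyond the scatter. The earlier step on the core of compound 1 does not predict this one, so the change does not carry over as a fixed increment between these two cores: the same change on two cores in this assay, a 1.7-fold higher number (0.22 log units; within the scatter) from compound 1 to compound 3 and an 8.1-fold lower number (0.91 log units; beyond the scatter) from compound 2 to compound 4, 13-fold (1.13 log units) apart, beyond the scatter of two such steps. This shows that, for these two pairs, the size of the step depends on the core that carries it, but two pairs give no rule for a third core and do not show which feature of the cores matters.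

Which part of the difference between the core of compound 1 and the core of compound 2 goes with this gap stays open. Also open, as far as these compounds go, is how a terminal amine or a longer chain in place of chloromethyl would behave on either core.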